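This account rests on a few compounds, and the source may have more. Where it says the series, first, only, none or still open, it means among the compounds named here.

In a functional assay on HT-29 cells (Homo sapiens) for inhibition, read by sulforhodamine B assay, with a stated time of 72 h (a lower number here means a stronger inhibitor, a higher number a weaker inhibitor), compound 3 `COc1cc2c(Nc3cccc(Br)c3)ncnc2cc1OCCCn1ccnc1[N+](=O)[O-]` gives 10900 nM, and compound 1 `COc1cc2c(Nc3ccc(F)c(Cl)c3)ncnc2cc1OCCCn1ccnc1[N+](=O)[O-]` gives 6140 nM. Going by the values given here, the one measured step here, a 1.8-fold higher number from compound 1 to compound 3 (0.25 log units; within the scatter), leaves the chain untouched. Compound 4 `COc1cc2c(Nc3cccc(Br)c3)ncnc2cc1OCCCCn1ccnc1[N+](=O)[O-]` changes the chain instead: (2-nitro-1H-imidazol-1-yl)methyl in place of 2-nitro-1H-imidazol-1-yl on a saturated chain carbon, three bonds along the chain from an oxygen on an aromatic ring. Among the compounds with values here, no measured step isolates this change. Within the data shown here, the only hint is compound 2 `C#Cc1cccc(Nc2ncnc3cc(OCCCCn4ccnc4[N+](=O)[O-])c(OC)cc23)c1`, which carries the chain of compound 4; compound 2 gives 2520 nM, lower than compound 3 beyond the scatter, although it differs from compound 3 elsewhere too. A modest move toward a lower number is therefore expected, and the estimated step is a 1.8-fold lower number from compound 3 to compound 4 (0.26 log units; within the scatter). For compound 4 the expected value is 6000 nM, with an estimated range of 2500 nM to 14000 nM.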

Compound 4, half-maximal inhibitory concentration: 4020 nM
Estimate against measurement, compound 4: 1.5-fold (0.17 log units) above, within the range that was stated.
By their numbers in this assay, from the lowest: compounds 2, 4, 1 and 3 (each within the scatter of the next, the first and the last beyond it).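

With the 3-bromophenyl group held fixed, the chain change now has a measured size in this assay: (2-nitro-1H-imidazol-1-yl)methyl in place of 2-nitro-1H-imidazol-1-yl gives a step beyond the scatter (a 2.7-fold lower number from compound 3 to compound 4 (0.43 log units; beyond the scatter)). On that same chain, bromo in place of ethynyl stays within the scatter (a 1.6-fold higher number from compound 2 to compound 4 (0.20 log units; within the scatter)), as did the aryl change on the shorter chain. Nothing measured here accounts for the chain step. From the compounds shown here alone, whether a longer chain would continue this move remains open. So does what an amine in place of the 2-nitro-1H-imidazol-1-yl group would give.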